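A few compounds are considered here, and "the series" means these few. Any claim that something is new, unique, unknown or untested is made for them only; others in the source may bear on it.

The measured compounds:
Compound 1, `COc1cccc(/C=C2\CCC/C(=C\c3ccccc3Br)C2=O)c1OC`: in a functional assay on HT-1080 cells (Homo sapiens) for cytotoxicity, read by MTT assay, with a stated time of 72 h (on this read-out higher numbers stand for weaker inhibition and lower numbers for stronger inhibition), compound 1 gives 10800 nM.
Compound 2, `COc1cccc(/C=C2\CCC/C(=C\c3ccc(Br)cc3)C2=O)c1OC`: in this assay compound 2 gives 13700 nM.
Compound 3, `COc1cccc(/C=C2\CCC/C(=C\c3cccc(O)c3)C2=O)c1OC`: in this assay compound 3 gives 8500 nM.

Among these three numbers compound 1 holds the second highest; its nearest neighbour is compound 2 and its furthest is compound 3, and both lie within the usual scatter of it. None of the three can be called more or less potent than another.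

Compound 4, `COc1cccc(/C=C2\CCC/C(=C\c3ccc(Cl)cc3Cl)C2=O)c1OC`, is not yet measured. It differs from compound 1 in one place: 2,4-dichlorophenyl in place of 2-bromophenyl on a double-bonded chain carbon bound to a double-bonded ring carbon. The change keeps a halogen on the phenyl group and alters only its kind and count.

Among the compounds with values here, two measured steps bear directly on this change, both at the same place: a 1.3-fold higher number from compound 1 to compound 2 (0.10 log units; within the scatter) and a 1.3-fold lower number from compound 1 to compound 3 (0.10 log units; within the scatter). The third, a 1.6-fold lower number from compound 2 to compound 3 (0.21 log units; within the scatter), is likewise small. Swapping one substituent on that phenyl for another has so far left the read-out unchanged beyond the scatter. Within the data shown here, no bearing step is beyond the scatter, so no step beyond the scatter is expected for compound 4 either. The expected step is a 1.1-fold lower number from compound 1 to compound 4 (0.03 log units; within the scatter). Compound 4 is estimated to give about 10000 nM in this assay, with a range from 4500 nM to 22000 nM.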

Compound 4, half-maximal inhibitory concentration: > 20000 nM
Compound 4: only a limit was reported (the forecaster's own chance of this, stated with the estimate: 5%); middle value at least 2.0-fold (0.30 log units) from the limit.
By their numbers in this assay, from the lowest: compounds 3, 1 and 2 (each within the scatter of the next). At a limit, above all of these: compound 4.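

In this assay compound 4 is reported only as a limit, > 20000 nM, and not as a number: the limit of > 20000 nM in this assay, at which 1 of the 4 values shown sits. Even so, that limit gives an at least 2.3-fold higher number from compound 3 to compound 4 (0.37 log units; beyond the scatter), the first step at this place, on a double-bonded chain carbon bound to a double-bonded ring carbon, that lies beyond the scatter, so the group carried here can move the read-out, which the earlier steps among the bromophenyl and hydroxyphenyl compounds did not show. As far as these compounds go, the other two steps, an at least 1.8-fold higher number from compound 1 to compound 4 (0.26 log units; that floor lies within the scatter) and an at least 1.4-fold higher number from compound 2 to compound 4 (0.16 log units; that floor lies within the scatter), have floors within the scatter, so compound 4 cannot yet be separated from either bromophenyl compound, and the true size of both steps remains unknown.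

From the compounds shown here alone, it remains open how far the read-out of compound 4 actually lies from the others, and whether the count of halogens or their kind goes with the change, a question that a single 2-chlorophenyl or 4-chlorophenyl group could address. Also open, going by these compounds, is what an amine or a carboxylic acid on this phenyl would do to the read-out.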